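The compounds below may be only part of what the source reports. "The series", "measured", "known", "first", "only" and "open" are said of these compounds alone.

For the measured compounds named here, in a functional assay on U-87MG ATCC cells for inhibition, with U-87 MG (Homo sapiens) as the target, read by sulforhodamine B assay, with a stated time of 72 h (a higher number here means that more compound is needed for the effect, a lower number that less compound is needed), two compounds have numbers so far. Compound 1 (`CCCCc1ccc(C(=O)/C=C/c2ccc([N+](=O)[O-])o2)cc1`) gives 5800 nM, and compound 2 (`CC(C)(C)c1ccc(C(=O)/C=C/c2ccco2)cc1`) gives 32300 nM. Compound 2 therefore holds the higher of the two numbers, and its gap to compound 1 lies beyond the usual scatter of repeated measurements.

The next compound to be tested is compound 3 (`CCCCc1ccc(C(=O)/C=C/c2ccco2)cc1`). It has butyl in place of tert-butyl on an aromatic carbon, para to a group of 9 heavy atoms: butyl in place of tert-butyl on an aromatic carbon. The two compounds have the same atoms, joined differently. Going by the values given here, no measured pair isolates this change, so the data offer no direct guide to its size. Butyl also appears in compound 1 at 5800 nM, but that compound differs from compound 2 in more than this one place, so it lends only weak support to a lower number. In this assay, no change beyond the scatter is expected, with at most a slight drift downward. The estimated step is a 1.5-fold lower number from compound 2 to compound 3 (0.17 log units; within the scatter). For compound 3, the expected value is 22000 nM, with an estimated range from 9000 nM to 50000 nM.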

Compound 3, half-maximal effective concentration: 12300 nM
Compound 3: middle estimate off by 1.8-fold (0.25 log units), on the high side, and the stated range covers the measured number.
By their numbers in this assay, from the lowest: compound 1; then compound 3; then compound 2.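

In this assay, the exchange of tert-butyl for butyl on an aromatic carbon, para to a group of 9 heavy atoms, now has a measured size: a 2.6-fold lower number from compound 2 to compound 3 (0.42 log units; beyond the scatter) shows that the same four carbons, joined differently at this position, move the number beyond the scatter and toward less compound being needed. For the compounds shown here, with butyl held constant, hydrogen in place of nitro gives a 2.1-fold higher number from compound 1 to compound 3 (0.33 log units; beyond the scatter), so a second place on the molecule also affects the number, and the nitro-bearing compound 1 is the one that needs less compound in this pair. The data at hand offer no measurement that would explain either step.

Going by these compounds, each step is read from a single pair of compounds, so it remains open whether either one would keep its size and direction with the other place changed, as with tert-butyl and nitro on one molecule. Also open, on these data alone, is how a longer chain such as hexyl in place of butyl, or an amine or a carboxylic acid in place of nitro, would shift the number.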